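A few compounds are considered here, and "the series" means these few. Any claim that something is new, unique, unknown or untested is made for them only; others in the source may bear on it.

Measured in a functional assay on MCF7 cells (Homo sapiens) for cytotoxicity, read by sulforhodamine B assay, with a stated time of 48 h; a lower number here means a stronger inhibitor, a higher number a weaker inhibitor:
Compound 1 `C=CCOc1cc(Br)ccc1C(=O)c1cccnc1`: > 100000 nM
Compound 2 `O=C(c1cccnc1)c1cc(F)ccc1O`: 27800 nM
Compound 3 `O=C(c1cccnc1)c1cc(Cl)ccc1O`: 29000 nM
Compound 4 `C=CCOc1ccccc1C(=O)c1cccnc1`: not yet measured

In this assay compound 1 gives > 100000 nM, which is a limit of the assay and not a number. Compound 1 thus stands at the limit of > 100000 nM in this assay, at which 1 of the 3 values shown sits.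

The next step leads to compound 4, with the change (hydrogen in place of bromo on an aromatic carbon), that is, hydrogen in place of bromo on an aromatic carbon. The nearest measured evidence is a 1.0-fold higher number from compound 2 to compound 3 (0.02 log units; within the scatter), a swap of chloro in place of fluoro on an aromatic carbon that stays within the scatter. That step exchanges one halogen for another and does not show the loss of a halogen, so it bears on this change only loosely. No step beyond the scatter is therefore expected in this assay, and a further limit is a likely outcome. The expected size of the change is an at least 1.1-fold lower number from compound 1 to compound 4 (0.04 log units; that floor lies within the scatter). For compound 4 the estimated value is 90000 nM, with an expected range of 40000 nM to 200000 nM.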

Compound 4, half-maximal inhibitory concentration: > 100000 nM
Compound 4 gave a limit, no number (the forecaster's own chance of this, stated with the estimate: 55%); at least 1.1-fold (0.04 log units) between middle value and limit.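

In this assay compound 1 and compound 4 both stand at a limit of the assay and not at a number, so no step can be read for hydrogen in place of bromo: the limit of > 100000 nM in this assay, at which 2 of the 4 values shown sit. The compounds shown leave open how far either compound lies beyond that limit.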